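The source may report more compounds than this note shows. Statements on the series, on what has been measured and on what is new or still open speak of the compounds shown alone.

Measured compounds in the series:
- compound 1 `CC(C)CCN(CCC(C)C)c1ccc(C(=O)N2CCc3ccc(OS(N)(=O)=O)cc3C2)cc1` — 90.8%
- compound 2 `CCN(Cc1ccccc1)Cc1ccc(S(=O)(=O)N2CCc3ccc(OS(N)(=O)=O)cc3C2)cc1` — 31%
- compound 3 `CCN(Cc1cccc(Br)c1)c1cccc(C(=O)N2CCc3ccc(OS(N)(=O)=O)cc3C2)c1` — 24.9%

In an assay on HEK293 cells for inhibition of Steryl-sulfatase (Homo sapiens), tested at 1 uM (a higher number here means a stronger effect of the compound at the concentration tested, a lower number a weaker effect), compound 3 stands lowest of the three numbers; compound 2 lies within the scatter of it, while compound 1 lies far above it, beyond the scatter. Compound 4 `CCN(Cc1ccccc1)c1cccc(C(=O)N2CCc3ccc(OS(N)(=O)=O)cc3C2)c1` differs from compound 3 in one place: hydrogen in place of bromo on an aromatic carbon. For the measured compounds named here, no measured pair isolates this change, so its size is not known from the data. Compound 2, which also carries a benzyl group without the bromo, gives 31% in this assay, close to compound 3. The step in this assay is therefore expected to be small, with no clear direction beyond the scatter. Compound 4 is expected to give 28%, estimated within 10% to 50%. The expected step is a number 3.1 percentage points higher from compound 3 to compound 4 (within the scatter).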

Compound 4, a percentage reported as inhibition, at one concentration (the size of the read-out at that concentration, not a potency): 69%
Estimate against measurement, compound 4: 41 percentage points below, and the stated range ends below it.
By their numbers in this assay, from the lowest: compounds 3 and 2 (each within the scatter of the next); then compound 4; then compound 1.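

In this assay the change from 3-bromobenzyl to benzyl gives a number 44.1 percentage points higher from compound 3 to compound 4 (beyond the scatter). For the compounds shown here, this is the first comparison that isolates a single place, and it shows that the read-out responds strongly to this aromatic carbon, with the bromo going with the lower effect and hydrogen with the higher. Nothing available explains the size of this step. Still open, as far as these compounds go, is whether fluoro, chloro or methoxy on this carbon would read like hydrogen or like bromo, and whether bromo elsewhere on this ring gives the same drop.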